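This account rests on a few compounds, and the source may have more. Where it says the series, first, only, none or still open, it means among the compounds named here.

Among the compounds with values here, compound 3 `C=CC1=C(C(=O)NC2CCCCC2)C(c2ccc(OC)c(OC)c2)OC1` is the one member of the series with a number: in a functional assay on SW480 cells (Homo sapiens) for cytotoxicity, read by MTT assay, with a stated time of 24 h (on this read-out lower numbers stand for stronger inhibition and higher numbers for weaker inhibition), compound 3 gives 19100 nM. Compound 1 `C=CC1=C(C(=O)O)C(c2ccc(OC)cc2)OC1` sits at the limit > 100000 nM in this assay. Compound 2 `C=CC1=C(C(=O)NC(C)(C)C)C(c2ccc(OC)cc2)OC1` also sits at the limit > 100000 nM. Within the data shown here, the single measured step, (tert-butyl)amino in place of hydroxy on a carbonyl carbon, a step that the two limits leave unreadable from compound 1 to compound 2, cannot be sized because of the limit of > 100000 nM in this assay, at which 2 of the 3 values shown sit.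

Compound 4 `C=CC1=C(C(=O)NC2CCCCC2)C(c2ccc(OC)cc2)OC1` differs from compound 3 by hydrogen in place of methoxy on an aromatic carbon. Among the measured compounds shown here, no measured step involves the same change, so nothing sizes it directly. For the measured compounds named here, compound 4 carries the same single methoxy as compound 1 and compound 2, both of which are limits, whereas compound 3 with two methoxy groups is the only compound with a reading; the amide group differs between those compounds, so the comparison is loose. A loss of potency is therefore expected, possibly reaching the limit. Compound 4 is estimated at 50000 nM, with a range from 15000 nM to 160000 nM. The expected step of a 2.6-fold higher number from compound 3 to compound 4 (0.42 log units; beyond the scatter) means a weakening beyond the scatter.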

Compound 4, half-maximal inhibitory concentration: > 100000 nM
Compound 4: a limit, no number; the forecaster's own chance of this, stated with the estimate: 45%; middle value at least 2.0-fold (0.30 log units) from the limit.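

In this assay, within the data shown here, the methoxy ortho to a methoxy group and meta to a large group is the first place where a single change can be sized: hydrogen in place of methoxy on an aromatic carbon gives an at least 5.2-fold higher number from compound 3 to compound 4 (0.71 log units; beyond the scatter), with the cyclohexyl amide unchanged. Compound 4 sits at a limit, > 100000 nM, so this size is a minimum and the true loss may be larger. The steps from compound 1 and from compound 2 to compound 4 cannot be read, because both ends of each step sit at a limit: the limit of > 100000 nM in this assay, at which 3 of the 4 values shown sit.

Open, from the compounds shown here alone, is whether an ethoxy, a hydroxy or a fluorine at this place would keep the reading of compound 3. Also open, going by these compounds, is whether the two methoxy groups would give a reading with a benzylamide or a morpholine amide on the carbonyl carbon.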